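Arylthiosemicarbazones of a quinoline aldehyde: ortho-fluoro to para-chloro

The compounds below may be only part of what the source reports. "The series", "measured", "known", "first", "only" and "open" are said of these compounds alone.

Measured so far:
- compound 1, `FC(F)(F)c1ccccc1NC(=S)N/N=C/c1ccc2ccccc2n1`: 20700 nM
- compound 2, `Fc1ccccc1NC(=S)N/N=C/c1ccc2ccccc2n1`: > 100000 nM

In a functional assay on SGC-7901 cells (Homo sapiens) for antiproliferative activity, read by sulforhodamine B assay, with a stated time of 72 h (on this read-out higher numbers stand for weaker inhibition and lower numbers for stronger inhibition), compound 1 gives 20700 nM. For compound 2 the value of > 100000 nM is a limit of the assay, not a number; the compound sits at the limit of > 100000 nM in this assay, at which 1 of the 2 values shown sits. The single measured step, an at least 4.8-fold higher number from compound 1 to compound 2 (0.68 log units; beyond the scatter), is beyond the scatter, so compound 2 stands as the weaker of the two on the numbers shown.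

Compound 3, `S=C(N/N=C/c1ccc2ccccc2n1)Nc1ccc(Cl)cc1`, differs from compound 2 by 4-chlorophenyl in place of 2-fluorophenyl on an amide-type nitrogen. For the measured compounds named here, no measured step covers the exchange of fluoro for chloro, nor a change in the position of the substituent on the phenyl ring; the only step in hand, from trifluoromethyl to fluoro, says just that the 2-fluorophenyl analogue falls off the scale. Compound 3 is therefore expected to return near compound 1 or between the two, with a step of an at least 2.8-fold lower number from compound 2 to compound 3 (0.45 log units; beyond the scatter) expected in this assay, and a real chance that it too is reported only as a limit. The estimate for compound 3 is 35000 nM, with a range from 8000 nM to 150000 nM.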

Compound 3, half-maximal inhibitory concentration: 87600 nM
Compound 3: the middle estimate sits 2.5-fold (0.40 log units) below what was measured, within the range that was stated.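

In this assay, as far as these compounds go, 4-chlorophenyl in place of 2-fluorophenyl on the amide-type nitrogen gives an at least 1.1-fold lower number from compound 2 to compound 3 (0.05 log units; that floor lies within the scatter), so this change cannot be said to shift the read-out in either direction, and the true size of the step stays unknown. Compound 2 remains a limit of the assay, not a number: the limit of > 100000 nM in this assay, at which 1 of the 3 values shown sits.

Compound 3 nevertheless carries a measured number, which gives the series a second measured value at this position: compound 1 gives 20700 nM, and compound 3 gives 87600 nM.

The step from 2-fluorophenyl to 4-chlorophenyl changes the halogen and its place on the phenyl ring together, so the compounds shown leave the two contributions unseparated; 4-fluorophenyl and 2-chlorophenyl on the same nitrogen would be the direct tests. Also open is how a phenyl ring carrying an amine or a carboxylic acid would read on the shared core, since every substituent shown here is a halogen or trifluoromethyl.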